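The source may report more compounds than this note shows. Statements on the series, on what has been measured and on what is new or still open speak of the compounds shown alone.

In a functional assay on HL-60 cells (Homo sapiens) for inhibition (on this read-out lower numbers stand for stronger inhibition and higher numbers for weaker inhibition), compound 1 `OC[C@H]1OC(n2cnc3c(-c4ccccn4)ncnc32)[C@H](O)[C@@H]1O` gives 5600 nM and compound 2 `Cc1ccsc1-c1ncnc2c1ncn2C1O[C@H](CO)[C@@H](O)[C@H]1O` gives 4500 nM. For the measured compounds named here, these are the only two numbers available, so compound 2 can be placed only against compound 1, and the two lie within the scatter of each other. Compound 3 `Cc1csc(-c2ncnc3c2ncn3C2O[C@H](CO)[C@@H](O)[C@H]2O)c1` keeps the shared core and alters only the methylthiophene group: 4-methylthiophen-2-yl in place of 3-methylthiophen-2-yl on an aromatic carbon. Here 4-methylthiophen-2-yl takes the place of 3-methylthiophen-2-yl. Going by the values given here, one measured step bears on this change, and only indirectly: replacing pyridin-2-yl with 3-methylthiophen-2-yl gave a 1.2-fold lower number from compound 1 to compound 2 (0.09 log units; within the scatter). Among the compounds with values here, no measured pair shows the effect of the methyl position alone, so no step beyond the scatter is expected in this assay, in either direction. The expected step is no change at the digits printed from compound 2 to compound 3 (within the scatter). Compound 3 is therefore estimated at 4500 nM, within a range of 1500 nM to 13000 nM.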

Compound 3, half-maximal inhibitory concentration: 5600 nM
The estimate for compound 3 lay 1.2-fold (0.09 log units) below the measured number; measured number inside the range.
By their numbers in this assay, from the lowest: compounds 2, 1 and 3 (each within the scatter of the next).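

The methyl group can now be followed on its own: going from 3-methylthiophen-2-yl to 4-methylthiophen-2-yl in this assay gives a 1.2-fold higher number from compound 2 to compound 3 (0.09 log units; within the scatter) and so leaves the number within the scatter. Exchanging pyridin-2-yl for 4-methylthiophen-2-yl gives no change at the digits printed from compound 1 to compound 3 (within the scatter) as well, so the three groups at this place, next to the ring nitrogen, cannot be told apart on this read-out. Nothing available offers an explanation for this sameness. Going by these compounds, whether an amine, a carboxylic acid or a longer alkyl chain at this position would shift the number beyond the scatter stays open. On these data alone, what the methyl group adds over a plain thiophen-2-yl also stays open.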